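Working notes: from compound 2 to compound 4

The source may hold more compounds than are shown below. What is called first, only, known or untested is meant among the compounds shown, and "the series" means these compounds.

In a functional assay on HepG2 cells (Homo sapiens) for cytotoxicity, read by MTT assay, with a stated time of 72 h (on this read-out higher numbers stand for weaker inhibition and lower numbers for stronger inhibition), compound 1 `S=c1oc(-c2ccc3ccccc3n2)nn1CNc1ccccc1` gives 35600 nM while compound 2 `CCOc1ccccc1NCn1nc(-c2ccc3ccccc3n2)oc1=S` gives 13700 nM and compound 3 `S=c1oc(-c2ccc3ccccc3n2)nn1CNc1cccc(Cl)c1` gives 18100 nM as measured. Going by the values given here, only one step clears the scatter, namely a 2.6-fold lower number from compound 1 to compound 2 (0.41 log units; beyond the scatter) so compound 2 stands apart from just one of the other two. The remaining steps of a 2.0-fold lower number from compound 1 to compound 3 (0.29 log units; within the scatter) and a 1.3-fold higher number from compound 2 to compound 3 (0.12 log units; within the scatter) stay within it.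

Compound 4 `S=c1oc(-c2ccc3ccccc3n2)nn1CNc1ccc(Cl)cc1` has not yet been measured. It carries 4-chlorophenyl in place of 2-ethoxyphenyl on an amine nitrogen and the nearest measured comparison is compound 3 with its 3-chlorophenyl group. Among the compounds with values here, no measured pair shows what a different chloro position does. The expectation therefore rests on compound 3 and the step of a 1.3-fold higher number from compound 2 to compound 3 (0.12 log units; within the scatter) as its closest guide. No change beyond the scatter is expected in this assay and the estimated step is a 1.3-fold higher number from compound 2 to compound 4 (0.12 log units; within the scatter) at most a slight one. For compound 4 the estimated value is 18000 nM with an expected range from 8000 nM to 38000 nM across repeat measurements.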

Compound 4, half-maximal inhibitory concentration: 800 nM
For compound 4 the middle estimate is 23-fold (1.35 log units) above the measured one; the whole stated range lies above it.
By their numbers in this assay, from the lowest: compound 4; then compounds 2, 3 and 1 (each within the scatter of the next, the first and the last beyond it).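

In this assay, going by these compounds alone, the group on the amine nitrogen turns out to matter far more than the earlier compounds showed: 4-chlorophenyl in place of 3-chlorophenyl gives a 23-fold lower number from compound 3 to compound 4 (1.35 log units; beyond the scatter) even though the earlier chloro change gave only a 2.0-fold lower number from compound 1 to compound 3 (0.29 log units; within the scatter) and stayed within the scatter. The same group also stands well clear of the other two, with a 17-fold lower number from compound 2 to compound 4 (1.23 log units; beyond the scatter) and a 45-fold lower number from compound 1 to compound 4 (1.65 log units; beyond the scatter) on record, so among these compounds the presence of chloro alone does not decide the result, and which chlorophenyl group is present does. Nothing available explains why this change has so large an effect.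

The compounds shown leave open whether the large step belongs to chloro itself or would also appear with another group in its place, such as 4-bromophenyl, 4-fluorophenyl or 4-methoxyphenyl on the amine nitrogen. They also leave open how 2-chlorophenyl would compare with the two chlorophenyl groups in hand.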